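Longer amine substituents on the shared core

The source may report more compounds than this note shows. Statements on the series, on what has been measured and on what is new or still open speak of the compounds shown alone.

Among the measured compounds shown here, compound 3 `CCCCN(CCCC)CCCCOc1c(-c2cc(OC)c(OC)c(OC)c2)oc2ccccc2c1=O` gives 7800 nM in a functional assay on LNCaP cells (Homo sapiens) for antiproliferative activity, read by WST assay, with a stated time of 3 days; on this read-out higher numbers stand for weaker inhibition and lower numbers for stronger inhibition; it stands second highest of the three numbers so far, its nearest neighbour being compound 2 `CCCN(CCC)CCCCCOc1c(-c2cc(OC)c(OC)c(OC)c2)oc2ccccc2c1=O` with 7600 nM, and its furthest compound 1 `CCCN(CCC)CCCCOc1c(-c2cc(OC)c(OC)c(OC)c2)oc2ccccc2c1=O` with 16800 nM. Compound 4 `CCCCCN(CCCCC)CCCOc1c(-c2cc(OC)c(OC)c(OC)c2)oc2ccccc2c1=O` is not yet measured; its difference from compound 3 is dipentylamino in place of (dibutylamino)methyl on a saturated chain carbon, three bonds along the chain from an oxygen on an aromatic ring.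

For the measured compounds named here, three measured steps bear on this. Lengthening the alkyl groups on the nitrogen gave a 2.2-fold lower number from compound 1 to compound 3 (0.33 log units; beyond the scatter); lengthening the chain between oxygen and nitrogen by one carbon gave a 2.2-fold lower number from compound 1 to compound 2 (0.34 log units; beyond the scatter); trading one for the other gave a 1.0-fold higher number from compound 2 to compound 3 (0.01 log units; within the scatter). The change to compound 4 again lengthens the nitrogen alkyls while shortening the chain by one carbon, adding one carbon overall, so only a small lowering of the number, if any, is expected, in line with the trade seen between compound 2 and compound 3. Compound 4 is therefore estimated at 5500 nM, expected range 2500 nM to 12000 nM, an expected step of a 1.4-fold lower number from compound 3 to compound 4 (0.15 log units; within the scatter).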

Compound 4, half-maximal inhibitory concentration: 5100 nM
For compound 4 the middle estimate is 1.1-fold (0.03 log units) above the measured one; low and high end bracket the measured number.
By their numbers in this assay, from the lowest: compounds 4, 2 and 3 (each within the scatter of the next); then compound 1.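

Notes on the amine end of the series: in this assay, placing dipentylamino on a saturated chain carbon, three bonds along the chain from an oxygen on an aromatic ring, gives a number that stays level with the two nearest compounds, with a 1.5-fold lower number from compound 3 to compound 4 (0.18 log units; within the scatter) and a 1.5-fold lower number from compound 2 to compound 4 (0.17 log units; within the scatter) both inside the usual scatter. The same change, read against the starting compound, gives a 3.3-fold lower number from compound 1 to compound 4 (0.52 log units; beyond the scatter), the largest step seen so far in the four compounds, so this position accepts the larger dipentylamino group without any loss on this read-out. No measurement in hand accounts for these differences.

Going by these compounds, it remains open how dipentylamino would read on the chain of compound 3, since compound 4 differs from it in both the nitrogen alkyl groups and the chain. Also open, on these data alone, is how a ring amine such as piperidine or morpholine, or a dihexylamino group, would behave at this position.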